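Changing the amide side chain: compound 2 to compound 3

This account rests on a few compounds, and the source may have more. Where it says the series, first, only, none or still open, it means among the compounds named here.

In a physicochemical assay for lipophilicity, at pH 7.4 (on this read-out higher numbers stand for higher lipophilicity and lower numbers for lower lipophilicity), compound 1 `Cc1cc(C(=O)Nc2c(F)cccc2F)nn1Cc1cc(Cl)ccc1OCc1ccccc1` gives 3.7. Compound 2 `Cc1cc(C(=O)NCc2ccncc2)nn1Cc1cc(Cl)ccc1OCc1ccccc1` gives > 3.7, which is a limit of the assay and not a number. The measurements so far show (the limit of > 3.7 in this assay, at which 1 of the 2 values shown sits).

For the measured compounds named here, the single measured step, a number no lower from compound 1 to compound 2 (the limit leaves the size open), places (pyridin-4-yl)methyl where 2,6-difluorophenyl stood on an amide-type nitrogen. Its size cannot be read, so compound 2 has no exact position on this scale.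

Compound 3 `Cc1cc(NC(=O)C2CCCO2)nn1Cc1cc(Cl)ccc1OCc1ccccc1` differs from compound 2 in one place: ((oxolan-2-yl)carbonyl)amino in place of ((pyridin-4-yl)methyl)carbamoyl on an aromatic carbon. Here ((oxolan-2-yl)carbonyl)amino replaces ((pyridin-4-yl)methyl)carbamoyl on an aromatic carbon of a five-membered aromatic ring with 2 nitrogen.

Going by the values given here, no measured step makes this exchange. The step of a number no lower from compound 1 to compound 2 (the limit leaves the size open) bears on it only loosely, as a change in the amide substituent, and offers no size to carry over. No step beyond the scatter is therefore expected in this assay, and no firm direction can be given. The expected change is a step that the limit leaves unreadable from compound 2 to compound 3, an estimate with a wide margin.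

For compound 3 the estimated value is 3.8, with an expected range from 3.3 to 4.3.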

Compound 3, distribution coefficient: > 3.7
Compound 3 was reported as a limit (the forecaster's own chance of this, stated with the estimate: 45%); the middle value is on the limit's open side.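

In this assay compound 3 gives > 3.7, which is a limit of the assay and not a number. This aromatic carbon now carries a second group reported only as a limit: ((oxolan-2-yl)carbonyl)amino, with a five-membered non-aromatic ring with 1 hetero atom, gives the same kind of result as ((pyridin-4-yl)methyl)carbamoyl, with its six-membered aromatic ring with 1 hetero atom. Placing ((oxolan-2-yl)carbonyl)amino where (2,6-difluorophenyl)carbamoyl stood on this aromatic carbon gives a number no lower from compound 1 to compound 3 (the limit leaves the size open). The size of this step and that of the step from compound 2 to compound 3 cannot be read, because these comparisons rest on limits: the limit of > 3.7 in this assay, at which 2 of the 3 values shown sit.

The compounds shown leave open how far the two groups differ in this assay, and whether the exchange moves the value at all. They also leave open whether a carboxylic acid or a simple amine on this aromatic carbon would give an exact number on this scale.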